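Working notes: compound 3 to compound 4 in the tail flick test

The source may report more compounds than this note shows. Statements on the series, on what has been measured and on what is new or still open speak of the compounds shown alone.

The three measured compounds were run in a functional assay on the whole organism (Tail, strain ICR) with Mus musculus as the target, in the tail flick test, with a stated time of 150 min, at a dose of 25 umol/kg by the oral route; on this read-out lower numbers stand for a weaker effect and higher numbers for a stronger effect at the one dose given:

Compound 1, `CC(C)[C@H](NC(=O)CN(c1nc(Cl)nc2[nH]cnc12)C1CC1)C(=O)OCc1ccccc1`, gives 17.9%.
Compound 2, `NC(=O)C[C@H](NC(=O)CN(c1nc(Cl)nc2[nH]cnc12)C1CC1)C(=O)O`, gives 7.51%.
Compound 3, `CC[C@H](C)[C@H](NC(=O)CN(c1nc(Cl)nc2[nH]cnc12)C1CC1)C(=O)OCc1ccccc1`, gives 6.9%.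

Compound 3 holds the lowest number of the three. Its nearest neighbour is compound 2, whose value lies within the scatter of it, so no order between those two can be stated. Among the compounds with values here, compound 1 stands beyond the scatter above compound 3, and that single pair is the only step available: a number 11 percentage points lower from compound 1 to compound 3 (beyond the scatter).

Compound 4, `NC(=O)C[C@H](NC(=O)CN(c1nc(Cl)nc2[nH]cnc12)C1CC1)C(=O)OCc1ccccc1`, is not yet measured. It differs from compound 3 as follows: carbamoylmethyl in place of sec-butyl on a saturated chain carbon bound to an amide-type nitrogen and a carbonyl carbon.

Within the data shown here, the one measured step concerns a smaller change at the same chain carbon and does not directly cover the group that enters here. Among the measured compounds shown here, what the numbers do show is that compound 2, which already carries carbamoylmethyl at that carbon, sits within the scatter of compound 3, although compound 2 differs from compound 4 in its ester as well, and no step between them is available. On that basis the expected step of a number 2.1 percentage points higher from compound 3 to compound 4 (within the scatter) is small, with no direction beyond the scatter claimed. Compound 4 is therefore estimated at 9%, with a range from 2% to 20%.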

Compound 4, a percentage reported as activity, at one dose (the size of the read-out at that dose, not a potency): 13.5%
For compound 4 the middle estimate is 4.5 percentage points below the measured one, within the range that was stated.
By their numbers in this assay, from the lowest: compounds 3, 2, 4 and 1 (each within the scatter of the next, the first and the last beyond it).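

Working notes on the chain carbon bound to an amide-type nitrogen and a carbonyl carbon, read in this assay: carbamoylmethyl in place of sec-butyl gives a number 6.6 percentage points higher from compound 3 to compound 4 (within the scatter) and carbamoylmethyl in place of isopropyl gives a number 4.4 percentage points lower from compound 1 to compound 4 (within the scatter) even though a number 11 percentage points lower from compound 1 to compound 3 (beyond the scatter) separates the two alkyl-bearing compounds, so compound 4 cannot be ordered against either of them. Benzyl in place of hydrogen on an oxygen next to a carbonyl group gives a number 6 percentage points higher from compound 2 to compound 4 (within the scatter) and shows that, with carbamoylmethyl at the chain carbon, this ester change does not separate the two compounds in this read-out. No measurement at hand bears on why these numbers fall as they do.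

Whether an amine, a carboxylic acid or a longer chain at the chain carbon would stand beyond the scatter of these compounds remains open. Also open, from the compounds shown here alone, is whether benzyl in place of hydrogen on that oxygen reads the same with sec-butyl or isopropyl at the chain carbon.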